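Permeability notes: switching the aryl substituent on the core

A few compounds are considered here, and "the series" means these few. Any claim that something is new, unique, unknown or untested is made for them only; others in the source may bear on it.

Measured so far:
compound 1, `COc1cccc(CNCCCNc2ccnc3cc(Cc4cccc(C(F)(F)F)c4)ccc23)c1O`, 23 10^-6 cm/s
compound 2, `COc1ccc(F)cc1CNCCCNc1ccnc2cc(-c3ccc(C(C)(C)C)cc3)ccc12`, 237 10^-6 cm/s

In an ADME assay for permeability, using PAMPA, with a stated time of 30 min, at pH 7.4 (a higher number here means that the compound crosses the layer faster, a lower number that the compound crosses the layer more slowly), compound 2 stands highest of the two numbers; compound 1 gives 23 10^-6 cm/s, a gap beyond the scatter. Compound 3, `COc1ccc(F)cc1CNCCCNc1ccnc2cc(Cc3cccc(C(F)(F)F)c3)ccc12`, differs from compound 2 by 3-(trifluoromethyl)benzyl in place of 4-(tert-butyl)phenyl on an aromatic carbon. Compound 3 otherwise keeps the side chain of compound 2, while compound 1 carries the same 3-(trifluoromethyl)benzyl. The step from compound 2 to compound 3 is expected to be a 2.4-fold lower number from compound 2 to compound 3 (0.37 log units; beyond the scatter), downward but smaller than the gap from compound 2 to compound 1. Compound 3 is estimated at 100 10^-6 cm/s, within 35 10^-6 cm/s to 250 10^-6 cm/s.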

Compound 3, apparent permeability in the ADME assay: 23 10^-6 cm/s
Beside the measured number, compound 3's estimate is 4.3-fold (0.64 log units) above it; the measured number lies below the stated range.
By their numbers in the ADME assay, from the lowest: compounds 1 and 3 (each within the scatter of the next); then compound 2.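

In the ADME assay the aromatic-carbon position dominates: 3-(trifluoromethyl)benzyl in place of 4-(tert-butyl)phenyl gives a 10-fold lower number from compound 2 to compound 3 (1.01 log units; beyond the scatter), whereas 5-fluoro-2-methoxyphenyl in place of 2-hydroxy-3-methoxyphenyl on the side chain gives no change at the digits printed from compound 1 to compound 3 (within the scatter). In a physicochemical assay for acid dissociation, compound 2 gives 9.47 and compound 3 gives 9.47, with no change at the digits printed from compound 2 to compound 3 (within the scatter). No supporting data bear on the cause of the large step.

Still open, on these data alone, is whether a 3-(trifluoromethyl)phenyl or a 4-(tert-butyl)benzyl group at this position would track compound 2 or compound 3 in the ADME assay.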